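A few compounds are considered here, and "the series" means these few. Any claim that something is new, unique, unknown or untested is made for them only; others in the source may bear on it.

Working notes on the series. Three compounds share the aminooxazole bearing a trifluoromethylphenyl group and differ in the amine-side ring and in the substituent on the five-membered ring. Compound 1 `CN(c1ncc(-c2ccc(C(F)(F)F)cc2)o1)c1cccc2c1CC(O)CC2` carries a methylated amine and a saturated hydroxylated bicyclic ring; in an in vitro functional assay on cells for antagonist activity at transient receptor potential cation channel subfamily V member 1 (Homo sapiens), read by FLIPR and calcium flux (a higher number here means a weaker inhibitor, a lower number a stronger inhibitor), compound 1 gives 277 nM. Compound 2 `Oc1ccc2cccc(Nc3ncc(-c4ccc(C(F)(F)F)cc4)o3)c2c1` has an unmethylated amine on a hydroxylated naphthalene, and in this assay compound 2 gives 10 nM. Compound 3 `CCc1nc(Nc2cccc3c2CC(O)CC3)oc1-c1ccc(C(F)(F)F)cc1` keeps the unmethylated amine on the saturated hydroxylated bicyclic ring and adds an ethyl group to the five-membered ring; in this assay compound 3 gives 2.1 nM, the lowest number of the three, the gaps to compound 2 and to compound 1 both lying beyond the scatter, so compound 3 stands as the strongest inhibitor so far.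

Compound 4 `OC1CCc2cccc(Nc3nc(-c4ccc(F)cc4)c(-c4ccc(C(F)(F)F)cc4)o3)c2C1` is not yet measured. It differs from compound 3 by 4-fluorophenyl in place of ethyl on an aromatic carbon. Among the compounds with values here, no measured pair covers this change, so no step can be read off. As far as these compounds go, a larger group at this position is untested; a modest weakening is expected, with the step from compound 3 to compound 4 estimated as a 2.4-fold higher number from compound 3 to compound 4 (0.38 log units; beyond the scatter). For compound 4 in this assay the expected value is 5 nM, between 1.2 nM and 25 nM.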

Compound 4, half-maximal inhibitory concentration: 1.3 nM
Estimate against measurement, compound 4: 3.8-fold (0.59 log units) above; low and high end bracket the measured number.
By their numbers in this assay, from the lowest: compounds 4 and 3 (each within the scatter of the next); then compound 2; then compound 1.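

In this assay the change of ethyl to 4-fluorophenyl, on the aromatic carbon next to the ring nitrogen, is a 1.6-fold lower number from compound 3 to compound 4 (0.21 log units; within the scatter), so compound 3 and compound 4 cannot be told apart. This position therefore accepts a group of 7 heavy atoms with its own six-membered aromatic ring as well as one of 2 heavy atoms, which compound 3 alone could not show. No supporting data bear on why the two groups read alike.

As far as these compounds go, whether this acceptance extends to a plain phenyl ring without fluorine, or to a longer alkyl chain, remains open. So does the outcome with an amine or a carboxylic acid at this position, as neither ethyl nor 4-fluorophenyl carries a hydrogen-bond donor or acceptor.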